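A few compounds are considered here, and "the series" means these few. Any claim that something is new, unique, unknown or untested is made for them only; others in the source may bear on it.

Three compounds share one core and differ only in the group carried on the piperidine nitrogen-bearing carbon. Compound 1 `CN(C1CCN(CCCc2c[nH]c3ccc(-n4cnnc4)cc23)CC1)S(=O)(=O)c1ccccc1` gives 1.5 nM in an assay on CHO cells for displacement of a labelled ligand from 5-hydroxytryptamine receptor 1D (Homo sapiens); a higher number here means a weaker inhibitor, a lower number a stronger inhibitor. Compound 2 `c1cc(CNC2CCN(CCCc3c[nH]c4ccc(-n5cnnc5)cc34)CC2)co1` gives 4.5 nM in this assay, and compound 3 `CC(=O)Nc1ccc(CNC2CCN(CCCc3c[nH]c4ccc(-n5cnnc5)cc34)CC2)cc1` gives 3 nM in this assay. Between these, the step of a 3.0-fold higher number from compound 1 to compound 2 (0.48 log units; beyond the scatter) is the only one beyond the scatter, whereas a 1.5-fold lower number from compound 2 to compound 3 (0.18 log units; within the scatter) is not. Compound 3 thus stands second highest of the three numbers, separated from compound 2 and from compound 1 only by amounts within the scatter.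

The step now followed leads to compound 4 `c1cncc(CNC2CCN(CCCc3c[nH]c4ccc(-n5cnnc5)cc34)CC2)c1`, where the change is pyridin-3-yl in place of 4-acetamidophenyl on a saturated chain carbon bound to an amine nitrogen. Going by the values given here, no measured step bears directly on this exchange; the closest comparison is the one in which the furan-3-yl of compound 2 gave way to the 4-acetamidophenyl of compound 3, and that step, a 1.5-fold lower number from compound 2 to compound 3 (0.18 log units; within the scatter), stayed within the scatter. Since swapping one small aromatic group for a larger substituted one on this chain carbon left the number essentially unchanged, compound 4 is expected to remain close to compound 3, with a step of a 1.3-fold higher number from compound 3 to compound 4 (0.12 log units; within the scatter) and no shift beyond the scatter. Compound 4 is therefore estimated at 4 nM, with a range from 1.5 nM to 10 nM.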

Compound 4, half-maximal inhibitory concentration: 35 nM
The estimate for compound 4 lay 8.8-fold (0.94 log units) below the measured number; measured number outside the range, above it.
By their numbers in this assay, from the lowest: compounds 1, 3 and 2 (each within the scatter of the next, the first and the last beyond it); then compound 4.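

On a saturated chain carbon bound to an amine nitrogen, the aromatic group proves far less interchangeable in this assay than the furan-3-yl and 4-acetamidophenyl pair had suggested: pyridin-3-yl gives a 12-fold higher number from compound 3 to compound 4 (1.07 log units; beyond the scatter) and a 7.8-fold higher number from compound 2 to compound 4 (0.89 log units; beyond the scatter), although those two earlier groups lay within the scatter of each other. The same group also gives a 23-fold higher number from compound 1 to compound 4 (1.37 log units; beyond the scatter), which makes compound 4 the weakest of the four, with its steps to all the others beyond the scatter. Nothing available here accounts for this loss.

The compounds shown leave open whether the step follows the ring nitrogen of pyridin-3-yl or the absence of the acetamido group; a plain phenyl on the same chain carbon, or a pyridin-3-yl carrying an acetamido group, would separate the two. Also open, going by these compounds, is whether the placement of the ring nitrogen matters, which pyridin-2-yl and pyridin-4-yl would test, and whether a thiophene would stay with furan-3-yl.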